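Phenol in place of carbamate on the distal oxygen

The source may report more compounds than this note shows. Statements on the series, on what has been measured and on what is new or still open speak of the compounds shown alone.

In an assay on cells for displacement of a labelled ligand from melatonin receptor type 1B (Homo sapiens), using the Cheng-Prusoff equation, with a stated time of 90 min (a lower number here means a stronger inhibitor, a higher number a weaker inhibitor), compound 2 `CC(=O)NCCN(C)c1cccc(OCCCCCCOc2cccc(OC(=O)NC3CCCCC3)c2)c1` gives 295 nM. Compound 1 `CC(=O)NCCN(C)c1cccc(OCCCCCCN)c1` gives 398 nM in this assay; the two numbers sit within the scatter of each other, so compound 2 cannot be ranked against compound 1. Compound 3 `CC(=O)NCCN(C)c1cccc(OCCCCCCOc2cccc(O)c2)c1` is not yet measured; it differs from compound 2 by hydrogen in place of cyclohexylcarbamoyl on an oxygen on an aromatic ring. For the measured compounds named here, no measured pair shows this change. Little movement beyond the scatter is expected for compound 3 in this assay, since compound 1 already gives 398 nM with a quite different chain end. Compound 3 is therefore expected at 400 nM, within 120 nM to 1300 nM, a step of a 1.4-fold higher number from compound 2 to compound 3 (0.13 log units; within the scatter) that stays within the scatter.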

Compound 3, inhibition constant: 331 nM
Estimate against measurement, compound 3: 1.2-fold (0.08 log units) above; the range from low to high includes it.
By their numbers in this assay, from the lowest: compounds 2, 3 and 1 (each within the scatter of the next).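

In this assay, hydrogen in place of cyclohexylcarbamoyl on the aromatic oxygen gives a 1.1-fold higher number from compound 2 to compound 3 (0.05 log units; within the scatter), so in this pair the cyclohexylcarbamoyl group makes no difference that can be read. At the chain end, 3-hydroxyphenoxy in place of amino gives a 1.2-fold lower number from compound 1 to compound 3 (0.08 log units; within the scatter), so these two ends cannot be told apart either. All three compounds therefore sit within the scatter, despite very different chain ends.

On these data alone, a methyl ether or a carboxylic acid on that ring, or a shorter or longer chain, remains open. Nothing at hand bears on why these numbers stay so close.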